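Trifluoromethyl for bromo: compound 3 to compound 4

The compounds below may be only part of what the source reports. "The series", "measured", "known", "first", "only" and "open" are said of these compounds alone.

Compound 1 `Cc1ccc(-n2nc(-c3ccc(C(F)(F)F)cc3O)nc2-c2ccccc2O)cc1`, compound 2 `Oc1cc(C(F)(F)F)ccc1-c1nc(-c2ccccc2O)n(-c2ccc(Cl)cc2)n1` and compound 3 `Oc1cc(C(F)(F)F)ccc1-c1nc(-c2ccccc2O)n(-c2ccc(Br)cc2)n1` share one core and differ only in the group on one aromatic carbon. In a functional assay on PC-12 cells (Rattus norvegicus) for cytotoxicity, read by MTT assay, with stated times of 2 h and 24 h, tested at 5 uM (on this read-out higher numbers stand for a stronger effect at the one concentration tested and lower numbers for a weaker effect), compound 1 gives 94.1%, compound 2 gives 87.3% and compound 3 gives 89.8%. Compound 3 stands second highest of the three numbers, but both of its steps lie within the scatter: a number 4.3 percentage points lower from compound 1 to compound 3 (within the scatter) and a number 2.5 percentage points higher from compound 2 to compound 3 (within the scatter). The remaining step, a number 6.8 percentage points lower from compound 1 to compound 2 (within the scatter), is within the scatter as well.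

Compound 4 `Oc1cc(C(F)(F)F)ccc1-c1nc(-c2ccccc2O)n(-c2ccc(C(F)(F)F)cc2)n1` is reached from compound 3 by a single change: trifluoromethyl in place of bromo on an aromatic carbon. For the measured compounds named here, the steps that bear on it are the three exchanges of the group on this same aromatic carbon, and none of them moved the read-out in this assay beyond the scatter. Nothing in these numbers therefore points to a step beyond the scatter for compound 4, in either direction. Compound 4 is expected to give about 89%, with a range from 78% to 97%. The step of a number 0.8 percentage points lower from compound 3 to compound 4 (within the scatter) is accordingly expected to be small.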

Compound 4, a percentage reported as activity, at one concentration (the size of the read-out at that concentration, not a potency): 90.5%
For compound 4 the middle estimate is 1.5 percentage points below the measured one, and the stated range covers the measured number.
By their numbers in this assay, from the lowest: compounds 2, 3, 4 and 1 (each within the scatter of the next).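

In this assay, trifluoromethyl on this aromatic carbon, para to a large group, gives no step beyond the scatter against any of the other three groups: a number 0.7 percentage points higher from compound 3 to compound 4 (within the scatter), a number 3.2 percentage points higher from compound 2 to compound 4 (within the scatter) and a number 3.6 percentage points lower from compound 1 to compound 4 (within the scatter). The exchange brings four heavy atoms in place of the single bromine, so the tolerance seen among methyl, chloro and bromo now extends to a group with more heavy atoms, and all four compounds lie within the scatter of one another. No measurement shown here bears on a reason for this.

Bromo and trifluoromethyl both count no hydrogen-bond donors or acceptors, so it remains open whether an amine or a carboxylic acid at this carbon would stay within the scatter. Also open, from the compounds shown here alone, is whether a longer chain here would do the same.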